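This account rests on a few compounds, and the source may have more. Where it says the series, first, only, none or still open, it means among the compounds named here.

Measured so far in a functional assay on LNCaP cells (Prostate gland, Homo sapiens) for antiproliferative activity, read by sulforhodamine B assay; on this read-out higher numbers stand for weaker inhibition and lower numbers for stronger inhibition:

compound 1, `CCCCCCCCCCCCCCCCCCNC(=O)[C@H]1CSC(CCCCCCCCCCCC)N1`: 11900 nM
compound 2, `CCCCCCCCCCCCCCCCCCNC(=O)[C@H]1CSC(c2ccc(Br)cc2)N1`: 5100 nM
compound 3, `CCCCCCCCCCCCCCCCCCNC(=O)[C@H]1CSC(c2ccc([N+](=O)[O-])cc2)N1`: 8400 nM

Compound 3 sits between the other two numbers, but its gaps to both are within the scatter: compound 1 is a step of a 1.4-fold lower number from compound 1 to compound 3 (0.15 log units; within the scatter) away, and compound 2 is a 1.6-fold higher number from compound 2 to compound 3 (0.22 log units; within the scatter) away. Only the switch from dodecyl to 4-bromophenyl, a 2.3-fold lower number from compound 1 to compound 2 (0.37 log units; beyond the scatter), stands out as a step beyond the scatter.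

Compound 4, `CCCCCCCCCCCCCCCCCCNC(=O)[C@H]1CSC(c2c(Cl)cccc2Cl)N1`, is not yet measured in this assay. The change from compound 3 is 2,6-dichlorophenyl in place of 4-nitrophenyl on a saturated ring carbon. Going by the values given here, no measured step replaces one aryl group with another bearing two substituents; the nearest guide is the bromo-for-nitro swap, a 1.6-fold higher number from compound 2 to compound 3 (0.22 log units; within the scatter), which stayed within the scatter, and the two aryl-for-dodecyl steps, which gave at most a modest shift. A step within the scatter or a small drop is therefore expected in this assay, without confidence in either direction.

The estimate for compound 4 is 6000 nM, with a range of 2500 nM to 15000 nM, corresponding to an expected step of a 1.4-fold lower number from compound 3 to compound 4 (0.15 log units; within the scatter).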

Compound 4, half-maximal inhibitory concentration: 13100 nM
Estimate against measurement, compound 4: 2.2-fold (0.34 log units) below, and the stated range covers the measured number.
By their numbers in this assay, from the lowest: compounds 2, 3, 1 and 4 (each within the scatter of the next, the first and the last beyond it).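

In this assay, the saturated ring carbon next to the ring nitrogen and next to the ring sulfur now shows a difference between two aryl groups: 2,6-dichlorophenyl in place of 4-bromophenyl gives a 2.6-fold higher number from compound 2 to compound 4 (0.41 log units; beyond the scatter), a step as modest as the only other one beyond the scatter. Against 4-nitrophenyl, a 1.6-fold higher number from compound 3 to compound 4 (0.19 log units; within the scatter), and against dodecyl, a 1.1-fold higher number from compound 1 to compound 4 (0.04 log units; within the scatter), the new group cannot be told apart, so an aryl group at this carbon does not by itself separate from dodecyl, and only 4-bromophenyl does so, although even 4-bromophenyl and 4-nitrophenyl remain within the scatter of each other. Nothing on hand gives a reason for these differences.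

Still open, from the compounds shown here alone, is how an unsubstituted phenyl, a pyridine ring, or a phenyl carrying an amine or a carboxylic acid would read at this carbon. Also open, going by these compounds, is whether the modest separation around 4-bromophenyl would hold with a shorter chain on the amide of the shared core.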